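From 4-chlorobenzyl to 3-nitrobenzyl: a cytotoxicity working note

The compounds below may be only part of what the source reports. "The series", "measured", "known", "first", "only" and "open" are said of these compounds alone.

Within the data shown here, in a toxicity assay on NIH3T3 cells (Mus musculus) for cytotoxicity, read by resazurin assay (on this read-out higher numbers stand for an effect only at larger amounts of compound and lower numbers for an effect already at smaller amounts), compound 1 (`COC(=O)c1ccc(NCc2cncn2Cc2ccc(Cl)cc2)cc1-c1ccccc1`) gives 25000 nM as the only actual number so far. Compound 2 (`Clc1ccc(NCc2cncn2Cc2ccc(-c3ccccc3)cc2)cc1-c1ccccc1`) reads > 1000 nM and this is a limit. Compound 3 (`Nc1cc(-c2ccccc2)ccc1Cn1cncc1CNc1ccc(Cl)c(-c2ccccc2)c1`) reads > 1000 nM and this is also a limit. Compound 1 therefore cannot be ranked against either of them.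

Compound 4 (`COC(=O)c1ccc(NCc2cncn2Cc2cccc([N+](=O)[O-])c2)cc1-c1ccccc1`) carries 3-nitrobenzyl where compound 1 carries 4-chlorobenzyl, which is 3-nitrophenyl in place of 4-chlorophenyl on a saturated chain carbon bound to an aromatic nitrogen on a saturated chain carbon bound to an aromatic nitrogen.

Among the measured compounds shown here, the only measured step is a step that the two limits leave unreadable from compound 2 to compound 3 for amino in place of hydrogen on an aromatic carbon. For the measured compounds named here, it has no readable size and concerns a different change, so no measured step sets a size or direction here. On that thin basis, no change at the digits printed from compound 1 to compound 4 (within the scatter) is expected to stay within the usual scatter in this assay with neither direction favoured. For compound 4 the estimate is 25000 nM with an expected range from 10000 nM to 60000 nM as the working figure.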

Compound 4, half-maximal effective concentration: > 10000 nM
Compound 4: a limit, no number (the forecaster's own chance of this, stated with the estimate: 35%); the middle value lies beyond the limit too.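

Compound 4 reads > 10000 nM, which is a limit and not a number, so no step can be read from compound 1 to compound 4. The compounds shown leave open whether 3-nitrobenzyl in place of 4-chlorobenzyl changes the cytotoxicity read-out at all, and in which direction.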